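Chloro in place of trifluoromethyl: what to expect for compound 4

The compounds below may be only part of what the source reports. "The series", "measured", "known", "first", "only" and "open" are said of these compounds alone.

Compound 1, `Cc1cccc(NC(=O)N[C@H](C)c2ccccc2)c1`: 47%
Compound 2, `C[C@@H](NC(=O)Nc1ccccc1C(F)(F)F)c1ccccc1`: 54%
Compound 3, `C[C@H](NC(=O)Nc1ccccc1C(F)(F)F)c1ccccc1`: 97%

Of the compounds shown here, three sharing one core have been measured in an ADME assay on the whole organism with Oryza sativa as the target, tested at 10 uM; a higher number here means a weaker effect of the compound at the concentration tested, a lower number a stronger effect. In this assay compound 1 gives 47%, compound 2 gives 54% and compound 3 gives 97%. Compound 3 therefore stands highest of the three, with the weakest effect, and its gap to each of the other two lies beyond the scatter. Among the measured compounds shown here, the one step measured between two compounds that differ in a single place is a number 43 percentage points higher from compound 2 to compound 3 (beyond the scatter), a step that rests solely on (the fact that compounds 2 and 3 differ only in the configuration as drawn).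

Compound 4, `C[C@H](NC(=O)Nc1ccccc1Cl)c1ccccc1`, is not yet measured. It differs from compound 3 by chloro in place of trifluoromethyl on an aromatic carbon. For the measured compounds named here, no measured step exchanges one group for another, so the configuration step gives no guide to the size of this change. With nothing pointing in either direction, compound 4 is expected to stay close to compound 3, with an estimate of 85%, ranging from 55% to 100%. That estimate means an expected step of a number 12 percentage points lower from compound 3 to compound 4 (beyond the scatter).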

Compound 4, a percentage reported as activity, at one concentration (the size of the read-out at that concentration, not a potency): 106%
For compound 4 the middle estimate is 21 percentage points below the measured one; the measured number lies above the stated range.
By their numbers in this assay, from the lowest: compounds 1 and 2 (each within the scatter of the next); then compounds 3 and 4 (each within the scatter of the next).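

Exchanging trifluoromethyl for chloro on this aromatic carbon, with the configuration of compound 3 kept, gives a number 9 percentage points higher from compound 3 to compound 4 (within the scatter) in this assay. Here a single chlorine atom thus cannot be told apart from the four heavy atoms of trifluoromethyl, whereas the change of configuration alone gave a number 43 percentage points higher from compound 2 to compound 3 (beyond the scatter). The compounds shown offer no measured property that would explain why this exchange leaves the number within the scatter.

As far as these compounds go, this is one pair of compounds, so it remains open whether the same exchange would also stay within the scatter in the configuration drawn in compound 2. From the compounds shown here alone, it also remains open whether a group of a different kind on this aromatic carbon, such as an amine or a carboxylic acid, would shift the number beyond the scatter.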